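Chloro in Place of Methoxy, Seen a Second Time

The compounds below may be only part of what the source reports. "The series", "measured", "known", "first", "only" and "open" are said of these compounds alone.

Of the compounds shown here, three have been measured in a physicochemical assay for lipophilicity, at pH 7.4; a lower number here means a more polar compound, a higher number a more lipophilic compound. Compound 1 `COc1ccc(C2Cc3nccn3C2)cc1` gives 2, compound 2 `Clc1ccc(C2Cc3nccn3C2)cc1` gives 2.6, and compound 3 `COc1ccccc1C1Cc2nccn2C1` gives 1.9. Compound 3 and compound 1 are made of the same atoms joined differently; the difference between the two cores is not broken down here. Compound 3 sits within the scatter of compound 1, while compound 2 lies beyond the scatter above compound 3.

Among the measured compounds there is just a single change at a single place. From compound 1 to compound 2 the change is chloro in place of methoxy on an aromatic carbon and the step it made was a number 0.60 log units higher from compound 1 to compound 2 (beyond the scatter).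

Compound 4 `Clc1ccccc1C1Cc2nccn2C1` has not yet been measured. Among the compounds with values here, it differs from compound 3 by chloro in place of methoxy on an aromatic carbon This is the same kind of change as the one from compound 1 to compound 2, yet not the same: in compound 2 the chloro sits para to a group of 8 heavy atoms, whereas in compound 4 it sits ortho to a group of 8 heavy atoms.

Because the earlier occurrence of this change gave a number 0.60 log units higher from compound 1 to compound 2 (beyond the scatter), the step in this assay is expected to be a number 0.60 log units higher from compound 3 to compound 4 (beyond the scatter). Resting on the value of compound 3, 1.9, compound 4 is therefore estimated at 2.5. The expected range for compound 4 runs from 2.1 to 2.9, wider than usual since the surroundings of the place differ.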

Compound 4, distribution coefficient: 2.6
Compound 4: middle estimate off by 0.10 log units, on the low side; low and high end bracket the measured number.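

In this assay, chloro in place of methoxy on an aromatic carbon gave a number 0.70 log units higher from compound 3 to compound 4 (beyond the scatter), a step in the same direction as a number 0.60 log units higher from compound 1 to compound 2 (beyond the scatter), and both steps lie beyond the scatter. The change therefore carried over from the core of compound 1 to the core of compound 3 with its direction kept, and on these two cores a step measured on one served as a usable guide to the step on the other. Within the data shown here, this rests on only two matched pairs and a single change, so it does not establish a rule for other cores, and nothing available here tells what lies behind either step.

The compounds shown carry only methoxy and chloro at this place, so it remains open how a different group, such as an amine, a carboxylic acid or a longer chain, would move the number in this assay on either core. As far as these compounds go, it is also open whether chloro in place of methoxy would keep its direction on a core other than these two, or how the same pairs would compare in any other kind of assay.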